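Benzoate esters on a shared core: the methoxy analogue

This account rests on a few compounds, and the source may have more. Where it says the series, first, only, none or still open, it means among the compounds named here.

Measured compounds:
- compound 1 `CC1=CC[C@H](C(C)C)c2cc(C)c(OC(=O)c3ccc(C)cc3)cc21`: 100% in a functional assay on K562 cells (Homo sapiens) for antiproliferative activity, read by sulforhodamine B assay, with a stated time of 48 h, tested at 50 uM; on this read-out higher numbers stand for more inhibition at the one concentration tested (going by the name of the read-out) and lower numbers for less inhibition
- compound 2 `CC1=CC[C@H](C(C)C)c2cc(C)c(OC(=O)c3cccc(Cl)c3)cc21`: "not active" (no number reported) in this assay, no number given

Compound 1 gives 100% in this assay. Compound 2 is reported as "not active" (no number reported) in this assay, with no number attached, so it stands at the lower end of the read-out without a figure to compare against. The two esters thus span the whole range of the read-out.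

Compound 3 `COc1ccc(C(=O)Oc2cc3c(cc2C)[C@@H](C(C)C)CC=C3C)cc1` is the next ester of the core. Relative to compound 2 the change is 4-methoxyphenyl in place of 3-chlorophenyl on a carbonyl carbon.

Within the data shown here, no step between measured compounds is available, so the size of the move from compound 2 to compound 3 in this assay cannot be read from a computed difference. The expectation is an increase beyond the scatter, toward the level of compound 1, because compound 1 with its ester gives 100% while compound 2 is reported as "not active" (no number reported); the outcome remains uncertain and a second result reported as not active cannot be excluded. Compound 3 is estimated at 55%, within 5% to 100%.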

Compound 3, a percentage reported as inhibition, at one concentration (the size of the read-out at that concentration, not a potency): 46.5%
For compound 3 the middle estimate is 8.5 percentage points above the measured one; low and high end bracket the measured number.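

Methoxy in place of methyl on an aromatic carbon gives a number 53.5 percentage points lower from compound 1 to compound 3 (beyond the scatter) in this assay and is the only change in this set with a step that can be read. It shows that this single exchange, with the rest of the ester unchanged, is enough to move the read-out well away from the level of compound 1. Compound 3 at 46.5% also adds a level between the two ends set by compounds 1 and 2, while the step from compound 2 to compound 3 cannot be read, as compound 2 is reported as "not active" with no number.

Open, from the compounds shown here alone, is how an ethoxy group, an amine or a carboxylic acid in place of the methoxy of the 4-methoxyphenyl group would read in this assay and whether any of them would hold the level of compound 1. No measurement at hand explains the differences among these three esters.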